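This account rests on a few compounds, and the source may have more. Where it says the series, first, only, none or still open, it means among the compounds named here.

Three allenic amines have been measured in an assay on forebrain for inhibition of Monoamine oxidase (Mus musculus); a higher number here means that more compound is needed for the effect, a lower number that less compound is needed. Compound 1, `C=C=CCN(C)Cc1ccccc1`, gives 17 umol/kg in this assay. Compound 2, `C=C=C(Cc1ccccc1)CN(C)C`, gives 54 umol/kg in this assay. Compound 3, `C=C=C(CN)Cc1ccc(OC)cc1`, gives 16 umol/kg in this assay. Among these three numbers compound 2 stands highest: compound 1 and compound 3 both lie lower, and in each case the gap is beyond the usual scatter of this assay, so compound 2 is the one that needs the most material for the half-maximal effect.

The next compound, compound 4, `C=C=C(CNC)Cc1ccccc1`, has not yet been measured. It differs from compound 2 in one place: hydrogen in place of methyl on an amine nitrogen, turning the dimethylamino group into a methylamino group. Among the compounds with values here, no pair of measured compounds shows this particular change, so there is no measured step to lean on. The primary amine of compound 3 and the tertiary amine of compound 1 both gave lower numbers than compound 2, but each of those pairs differs in more than the amine, so no direction is fixed from them.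

Compound 4 is expected to give about 30 umol/kg in this assay, with a likely range from 10 umol/kg to 90 umol/kg. The expected step is a 1.8-fold lower number from compound 2 to compound 4 (0.26 log units; within the scatter), a modest lowering that may not clear the scatter.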

Compound 4, dose for half-maximal effect: 11 umol/kg
For compound 4 the middle estimate is 2.7-fold (0.44 log units) above the measured one; the range from low to high includes it.
By their numbers in this assay, from the lowest: compounds 4, 3 and 1 (each within the scatter of the next); then compound 2.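

In this assay, within the data shown here, the change from dimethylamino to methylamino gives the first step in this set that can be read at a single place: a 4.9-fold lower number from compound 2 to compound 4 (0.69 log units; beyond the scatter). It shows that this amine nitrogen, whose other neighbours are saturated chain carbons, is a place where the loss of one methyl, a single heavy atom, goes with a change beyond the usual scatter, and that the direction is toward less compound being needed. Nothing available here accounts for why this change lowers the number.

On these data alone, this reading rests on one pair on one core, so it remains open whether hydrogen in place of methyl on an amine nitrogen would give a step of similar size and direction on the other cores in the set. As far as these compounds go, it also remains open how the number would respond to an ethyl group or a longer chain on this nitrogen, or to a primary amine on the core of compound 4, since these would show whether the trend continues in either direction.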